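A few compounds are considered here, and "the series" means these few. Any claim that something is new, unique, unknown or untested is made for them only; others in the source may bear on it.

Measured compounds in an assay on HEK293 cells for inhibition of Steryl-sulfatase (Homo sapiens), tested at 1 uM; on this read-out lower numbers stand for a weaker effect and higher numbers for a stronger effect at the one concentration tested:
compound 1 `CCN(Cc1ccccc1)c1cccc(C(=O)N2CCc3ccc(OS(N)(=O)=O)cc3C2)c1` — 69%
compound 2 `CCN(Cc1ccc(Br)cc1)c1cccc(C(=O)N2CCc3ccc(OS(N)(=O)=O)cc3C2)c1` — 84.5%
compound 3 `CCN(Cc1ccncc1)c1cccc(C(=O)N2CCc3ccc(OS(N)(=O)=O)cc3C2)c1` — 52.8%

Compound 1 stands second highest of the three: compound 2 sits higher, a number 15.5 percentage points higher from compound 1 to compound 2 (beyond the scatter), and compound 3 sits lower, a number 16.2 percentage points lower from compound 1 to compound 3 (beyond the scatter). Compound 4 `CN(C)CCN(Cc1ccccc1)c1cccc(C(=O)N2CCc3ccc(OS(N)(=O)=O)cc3C2)c1` differs from compound 1 by dimethylamino in place of hydrogen on a saturated chain carbon, two bonds along the chain from a nitrogen on an aromatic ring. Neither measured step touches this chain: the step to compound 2 alters an aromatic carbon, the step to compound 3 swaps the aryl group on the chain carbon bound to the ring nitrogen, and a number 31.7 percentage points lower from compound 2 to compound 3 (beyond the scatter) combines both. Among the compounds with values here, no measured step therefore bears directly on the change to compound 4, and no step beyond the scatter is expected in this assay. Compound 4 is estimated at 63% (range 42% to 80%), an expected step of a number 6 percentage points lower from compound 1 to compound 4 (within the scatter).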

Compound 4, a percentage reported as inhibition, at one concentration (the size of the read-out at that concentration, not a potency): 28.6%
Beside the measured number, compound 4's estimate is 34.4 percentage points above it; measured number below the stated range.
By their numbers in this assay, from the lowest: compound 4; then compound 3; then compound 1; then compound 2.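

In this assay, changing ethyl to 2-(dimethylamino)ethyl, on the nitrogen on an aromatic ring, gives a number 40.4 percentage points lower from compound 1 to compound 4 (beyond the scatter). Within the data shown here, this chain is therefore not a neutral site for this change, a point the aryl changes in the earlier compounds could not show. No evidence on hand bears on the reason for this loss.

The compounds shown do not separate the terminal dimethylamino group from the longer chain itself, so how a butyl chain or a 2-methoxyethyl chain would read here remains open. Also open, going by these compounds, is whether the 4-bromophenyl group would keep its effect alongside 2-(dimethylamino)ethyl.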